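Trifluoroethyl to hexyl at the end of the chain

The source may hold more compounds than are shown below. What is called first, only, known or untested is meant among the compounds shown, and "the series" means these compounds.

- compound 1 `COc1cc2ncnc(-n3nc(-c4ccccn4)nc3N)c2cc1OCCCCNC(=O)OC(C)(C)C` - 500 nM
- compound 2 `CCOC(=O)NCCCOc1cc2c(-n3nc(-c4ccccn4)nc3N)ncnc2cc1OC` - 16000 nM
- compound 3 `COc1cc2ncnc(-n3nc(-c4ccccn4)nc3N)c2cc1OCCCNC(=O)OCC(F)(F)F` - 100 nM

In a physicochemical assay for solubility, in phosphate buffer, with a stated time of 18 h, at pH 7.4 (a higher number here means a more soluble compound, a lower number a less soluble compound), compound 3 stands lowest of the three at 100 nM.

Compound 4 `CCCCCCOC(=O)NCCCOc1cc2c(-n3nc(-c4ccccn4)nc3N)ncnc2cc1OC` differs from compound 3 in one place: pentyl in place of trifluoromethyl on a saturated chain carbon bound to an oxygen next to a carbonyl group. This puts pentyl in place of trifluoromethyl on a saturated chain carbon bound to an oxygen next to a carbonyl group.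

Within the data shown here, the only measured step at this place is large: a 160-fold lower number from compound 2 to compound 3 (2.20 log units; beyond the scatter). Among the measured compounds shown here, it shows that the number can move far on a change here, but no measured compound carries pentyl, so it fixes no direction. The steps of a 32-fold higher number from compound 1 to compound 2 (1.51 log units; beyond the scatter) and a 5.0-fold lower number from compound 1 to compound 3 (0.70 log units; beyond the scatter) also alter the chain, and bear on the question less directly. Compound 1 and compound 3 both lie well below compound 2, so a return towards compound 2 is not expected, though the evidence is thin.

The expected change in this assay is a 1.4-fold lower number from compound 3 to compound 4 (0.15 log units; within the scatter), a shift not beyond the scatter. The estimate for compound 4 is 70 nM, with an expected range of 15 nM to 400 nM.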

Compound 4, solubility: 1000 nM
For compound 4 the middle estimate is 14-fold (1.15 log units) below the measured one; measured number outside the range, above it.
By their numbers in this assay, from the lowest: compound 3; then compounds 1 and 4 (each within the scatter of the next); then compound 2.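

Pentyl in place of trifluoromethyl on a saturated chain carbon bound to an oxygen next to a carbonyl group gives a 10-fold higher number from compound 3 to compound 4 (1.00 log units; beyond the scatter) in this assay, so the number at this place can also rise from the trifluoromethyl level, and the direction depends on the group that enters. That rise stops short of the top of the set: a 16-fold lower number from compound 2 to compound 4 (1.20 log units; beyond the scatter), while the comparison with the tert-butoxycarbonyl chain gives a 2.0-fold higher number from compound 1 to compound 4 (0.30 log units; within the scatter), which does not separate those two compounds. Nothing measured here accounts for these steps.

On these data alone, whether a longer chain such as octyl would follow hexyl in this assay remains open. So does the effect of an amine or a carboxylic acid at the end of the chain.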